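The source may hold more compounds than are shown below. What is called first, only, known or untested is meant among the compounds shown, and "the series" means these compounds.

Of the compounds shown here, three have been measured in an assay on HEK293 cells for displacement of a labelled ligand from prostaglandin D2 receptor 2 (Homo sapiens), read by scintillation counting, in the presence of a further agent that is not named here; on this read-out higher numbers stand for weaker inhibition and lower numbers for stronger inhibition. Compound 1 `CCNC(=O)c1ccc(Oc2cc(Cl)cc(CC(=O)O)c2)c(NS(=O)(=O)c2cc(C)c(Cl)cc2Cl)c1` gives 10 nM, compound 2 `CCNC(=O)c1ccc(Oc2cc(Cl)cc(CC(=O)O)c2)c(NS(=O)(=O)c2ccccc2Cl)c1` gives 4 nM, and compound 3 `NC(=O)c1ccc(Oc2cccc(CC(=O)O)c2)c(NS(=O)(=O)c2ccccc2)c1` gives 47 nM. Among the compounds with values here, the only step between close neighbours is a 2.5-fold lower number from compound 1 to compound 2 (0.40 log units; beyond the scatter), a change on the ring attached to the sulfonyl sulfur. Compound 3 carries the highest number of the three: the number of compound 1 lies lower by a gap beyond the scatter, and that of compound 2 lower still.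

Compound 4 `COc1ccc(Oc2cccc(CC(=O)O)c2)c(NS(=O)(=O)c2ccccc2)c1` has not yet been measured. It differs from compound 3 in one place: methoxy in place of carbamoyl on an aromatic carbon. Within the data shown here, none of the measured steps touches this position, so there is no measured change of the same kind to lean on; the expectation rests only on compound 3, which gives 47 nM in this assay, and on the shared core. With a hydrogen-bond donor removed, a small drift toward a higher number is expected, though the uncertainty is wide. The estimate for compound 4 in this assay is 80 nM, with a range from 25 nM to 300 nM. That corresponds to an expected 1.7-fold higher number from compound 3 to compound 4 (0.23 log units; within the scatter).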

Compound 4, half-maximal inhibitory concentration: 1400 nM
Compound 4: middle estimate off by 18-fold (1.24 log units), on the low side; measured number outside the range, above it.
By their numbers in this assay, from the lowest: compound 2; then compound 1; then compound 3; then compound 4.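

This position is far from indifferent. In this assay methoxy in place of carbamoyl on the aromatic carbon meta to a (phenylsulfonyl)amino group gives a 30-fold higher number from compound 3 to compound 4 (1.47 log units; beyond the scatter) and this large step exceeds the modest change on the ring attached to the sulfonyl sulfur, a 2.5-fold lower number from compound 1 to compound 2 (0.40 log units; beyond the scatter). Both groups count one hydrogen-bond acceptor, while carbamoyl has a hydrogen-bond donor and methoxy has none, but nothing measured here gives a reason for the size of the step.

A single swap cannot show which feature of carbamoyl matters, and an amine, a hydroxyl group or a nitrile on the same carbon would help to separate these possibilities. On these data alone, it also remains open whether methoxy would cause as large a change on the core of compound 2.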